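Pyran amides at the ceiling of a cytotoxicity assay

The compounds below may be only part of what the source reports. "The series", "measured", "known", "first", "only" and "open" are said of these compounds alone.

Compound 1, `C=CC1=C(C(=O)NCCCCC)C(c2ccc(OC)cc2)OC1`, gives in a functional assay on SW480 cells (Homo sapiens) for cytotoxicity, read by MTT assay, with a stated time of 24 h (a higher number here means a weaker inhibitor, a lower number a stronger inhibitor), a value of > 100000 nM, which is a limit of the assay and not a number.
Compound 2, `C=CC1=C(C(=O)Nc2ccccc2)C(c2ccc(Cl)c(Cl)c2)OC1`, gives in this assay a value of > 100000 nM, again a limit.
Compound 3, `C=CC1=C(C(=O)NCc2ccccc2)C(c2ccc(Cl)c(Cl)c2)OC1`, gives in this assay a value of > 100000 nM, also a limit.

Compound 1 therefore stands nowhere in particular: it sits at the ceiling of this assay, and the other two measured compounds sit at the same ceiling (the limit of > 100000 nM in this assay, at which 3 of the 3 values shown sit). Among the measured compounds shown here, the only measured step between compounds that differ in one place, a step that the two limits leave unreadable from compound 2 to compound 3, has no readable size, as both of its ends are limits (the limit of > 100000 nM in this assay, at which 3 of the 3 values shown sit).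

Compound 4, `C=CC1=C(C(=O)NCc2ccc(C)cc2)C(c2ccc(OC)cc2)OC1`, differs from compound 1 in this way: 4-methylphenyl in place of butyl on a saturated chain carbon bound to an amide-type nitrogen. For the measured compounds named here, no measured step bears directly on this change. Going by the values given here, the one step that touches the same part of the molecule, a step that the two limits leave unreadable from compound 2 to compound 3, left both compounds at the ceiling, and that is the only guidance available.

Compound 4 is therefore expected to remain at or near the ceiling of this assay, with an estimated value of 150000 nM (range 60000 nM to 500000 nM). This expectation corresponds to an estimated step that the limit leaves unreadable from compound 1 to compound 4.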

Compound 4, half-maximal inhibitory concentration: 31700 nM
Estimate against measurement, compound 4: 4.7-fold (0.68 log units) above, outside the stated range (below it).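

Among the compounds shown here, compound 4 is the only compound so far to give a real number in this assay, which shows that this end of the molecule can move the read-out: the exchange of pentyl for 4-methylbenzyl gives an at least 3.1-fold lower number from compound 1 to compound 4 (0.49 log units; beyond the scatter). The value of compound 1, > 100000 nM, is a limit and not a number, so this step gives only the smallest size the change could have. The earlier step at this part of the molecule cannot be read, and the ceiling still holds most of the series: the limit of > 100000 nM in this assay, at which 3 of the 4 values shown sit.

On these data alone, it remains open whether the gain needs an aromatic ring at this place, or whether a longer chain such as octyl would also bring the number down, and whether an amine or a carboxylic acid in place of the methyl of 4-methylphenyl would keep it. Also open, as far as these compounds go, is whether 4-methylphenyl at this place would have the same effect on the dichlorophenyl-bearing core of compound 3.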